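Thiophene for Amine on a Shared Indole-Free Core? No — Shared Core Step

This account rests on a few compounds, and the source may have more. Where it says the series, first, only, none or still open, it means among the compounds named here.

Compound 1, `Brc1ccc2ccn(CCN3CCNCC3)c2c1`, gives 61%.
Compound 2, `Brc1ccc2ccn(CCN3CCCN4CCCCC4C3)c2c1`, gives 99%.
Compound 3, `CN1CCCN(CCn2ccc3ccc(N)cc32)CC1`, gives 0%.

All three values come from an assay on HEK293 cells for binding affinity to 5-hydroxytryptamine receptor 7 (Homo sapiens), read by radioligand binding, tested at 1 uM; a lower number here means less inhibition, a higher number more inhibition at the concentration tested (going by the name of the read-out). Compound 3 stands lowest of the three numbers. Its nearest neighbour is compound 1, whose number is higher by an amount beyond the usual scatter, and the furthest is compound 2, higher still and likewise beyond the scatter. Compound 1 and compound 2 each carry a bromine on the shared core and show strong inhibition, whereas compound 3 carries an amino group there and shows none.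

Compound 4, `CN1CCCN(CCn2ccc3ccc(-c4ccsc4)cc32)CC1`, has not yet been measured. It differs from compound 3 in one place: thiophen-3-yl in place of amino on an aromatic carbon. For the measured compounds named here, no step between measured compounds is known for this change, so its effect is uncertain. Given that compound 3 gives 0%, there is room only upward or for no change. The expectation is a moderate rise, a number 35 percentage points higher from compound 3 to compound 4 (beyond the scatter), with compound 4 estimated at 35% within 5% to 75%.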

Compound 4, a percentage reported as inhibition, at one concentration (the size of the read-out at that concentration, not a potency): 68%
For compound 4 the middle estimate is 33 percentage points below the measured one, and the stated range covers the measured number.
By their numbers in this assay, from the lowest: compound 3; then compounds 1 and 4 (each within the scatter of the next); then compound 2.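

In this assay, for the compounds shown here, thiophen-3-yl in place of amino on this aromatic carbon gives a number 68 percentage points higher from compound 3 to compound 4 (beyond the scatter), a large step and the first direct reading of this position, as no earlier pair differed in one place only. The group on this carbon can therefore, on its own, decide whether the compound shows inhibition at the concentration tested. The change removes a hydrogen-bond donor and brings in a five-membered aromatic ring containing sulfur, but no supporting data explain the rise. 

On these data alone, it remains open whether the gain depends on the thiophene ring or simply on the loss of the amino group; a phenyl ring, a thiophen-2-yl group or a plain hydrogen on this carbon would help separate these readings. One step also cannot show whether the same swap would act alike with a different amine side chain.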